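The source may hold more compounds than are shown below. What is called first, only, known or untested is meant among the compounds shown, and "the series" means these compounds.

In a functional assay on HL-60 cells (Homo sapiens) for cytotoxicity, read by MTT assay, with a stated time of 4 days (on this read-out higher numbers stand for weaker inhibition and lower numbers for stronger inhibition), compound 3 `C=C1C(=O)[C@]23C[C@@]1(O)CC[C@H]2c1ccc(O)c(C)c1[C@@H]3Cn1cc(-c2ccc(Cl)cc2)nn1` gives 690 nM. On the numbers shown it sits second highest of the three: compound 2 `C=C1C(=O)[C@]23C[C@@]1(O)CC[C@H]2c1ccc(O)c(C)c1[C@@H]3Cn1cc(-c2ccc(F)cc2)nn1` gives 660 nM, and compound 1 `C=C1C(=O)[C@]23C[C@@]1(O)CC[C@H]2c1ccc(O)c(C)c1[C@@H]3Cn1cc(-c2ccccn2)nn1` gives 1970 nM. The steps of a 3.0-fold lower number from compound 1 to compound 2 (0.47 log units; beyond the scatter) and a 2.9-fold lower number from compound 1 to compound 3 (0.46 log units; beyond the scatter) both replace pyridin-2-yl with 4-fluorophenyl or 4-chlorophenyl, whereas the step of a 1.0-fold higher number from compound 2 to compound 3 (0.02 log units; within the scatter) exchanges only the group on that phenyl ring. Compound 4 `C=C1C(=O)[C@]23C[C@@]1(O)CC[C@H]2c1ccc(O)c(C)c1[C@@H]3Cn1cc(-c2ccc(OC)cc2)nn1` carries methoxy in place of chloro on an aromatic carbon. Among the compounds with values here, only the fluoro-to-chloro exchange bears directly on this change, and it stayed within the scatter; no measured step covers methoxy itself. The expected step of a 1.0-fold higher number from compound 3 to compound 4 (0.01 log units; within the scatter) is therefore none beyond the scatter. Compound 4 is estimated at 700 nM in this assay, with a range of 330 nM to 1500 nM.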

Compound 4, half-maximal inhibitory concentration: 1150 nM
Beside the measured number, compound 4's estimate is 1.6-fold (0.22 log units) below it; the measured number falls inside the stated range.
By their numbers in this assay, from the lowest: compounds 2, 3, 4 and 1 (each within the scatter of the next, the first and the last beyond it).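

Methoxy at this position stays within the scatter of both halogens in this assay (a 1.7-fold higher number from compound 3 to compound 4 (0.22 log units; within the scatter); a 1.7-fold higher number from compound 2 to compound 4 (0.24 log units; within the scatter)). Unlike 4-fluorophenyl and 4-chlorophenyl, 4-methoxyphenyl is not separated beyond the scatter from pyridin-2-yl (a 1.7-fold lower number from compound 1 to compound 4 (0.23 log units; within the scatter)). No supporting evidence bears on this result.

The compounds shown leave open whether an amine or a carboxylic acid on this phenyl ring would stay within the scatter of these substituents. They also leave open whether a longer alkoxy chain would separate from methoxy.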